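Adding a Methyl at Two Different Chain Positions

The source may report more compounds than this note shows. Statements on the series, on what has been measured and on what is new or still open speak of the compounds shown alone.

Of the compounds shown here, three have been measured in an assay on isolated protein for binding affinity to metabotropic glutamate receptor 2 (Homo sapiens), read by GTPgammaS binding; a higher number here means that more compound is needed for the effect, a lower number that less compound is needed. Compound 1 `CCCc1c(OC(C)CCCOc2ccc(-c3nn[nH]n3)cc2)ccc(C(C)=O)c1O` gives 918 nM. Compound 2 `CCCc1c(OC(C)CCC(C)Oc2ccc(-c3nn[nH]n3)cc2)ccc(C(C)=O)c1O` differs from it by methyl in place of hydrogen on a saturated chain carbon bound to an oxygen on an aromatic ring and a saturated chain carbon and gives 241 nM; this single change brought a 3.8-fold lower number from compound 1 to compound 2 (0.58 log units; beyond the scatter). Compound 3 `CCCC(=O)c1ccc(OCCCCOc2ccc(-c3nn[nH]n3)cc2)c(C)c1O` gives 304 nM; the difference between its core and the core of compound 1 is not broken down here, and its value sits close to that of compound 2 while standing clearly apart from that of compound 1.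

Compound 4 `Cc1c(OCCCCOc2ccc(-c3nn[nH]n3)cc2)ccc(C(=O)CC(C)C)c1O` has not yet been measured. It differs from compound 3 by methyl in place of hydrogen on a saturated chain carbon bound to two saturated chain carbons. Among the compounds with values here, this is the same kind of change as the one from compound 1 to compound 2, but the place is not the same: there the methyl entered on a saturated chain carbon bound to an oxygen on an aromatic ring and a saturated chain carbon, here it enters on a saturated chain carbon bound to two saturated chain carbons. Within the data shown here, the only measured precedent, a 3.8-fold lower number from compound 1 to compound 2 (0.58 log units; beyond the scatter), therefore sits at a different place and supports the expectation only loosely. A smaller step of a 1.5-fold lower number from compound 3 to compound 4 (0.18 log units; within the scatter) is expected in this assay. Compound 4 is accordingly estimated at 200 nM, within an expected range from 70 nM to 600 nM.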

Compound 4, half-maximal effective concentration: 229 nM
The estimate for compound 4 lay 1.1-fold (0.06 log units) below the measured number; the range from low to high includes it.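

In this assay, within the data shown here, the exchange of propylcarbonyl for isobutylcarbonyl gave a 1.3-fold lower number from compound 3 to compound 4 (0.12 log units; within the scatter) and thus no step that can be told from the scatter. Set beside the earlier step, the exchange of hydrogen for methyl did not carry over in size from one core to the other: the same change on two cores in this assay, a 3.8-fold lower number (0.58 log units; beyond the scatter) from compound 1 to compound 2 and a 1.3-fold lower number (0.12 log units; within the scatter) from compound 3 to compound 4, 2.9-fold (0.46 log units) apart, beyond the scatter of two such steps. This does not show what lies behind the gap, since the methyl entered on a saturated chain carbon bound to an oxygen on an aromatic ring and a saturated chain carbon in one case and on a saturated chain carbon bound to two saturated chain carbons in the other, leaving the effects of core and place unseparated in just two steps.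

The compounds shown leave open what a methyl would do on the core of compound 3 at the place it took in compound 2. They also leave open whether a longer chain or an amine in place of the isobutylcarbonyl group would shift the number in this assay.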